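This account rests on a few compounds, and the source may have more. Where it says the series, first, only, none or still open, it means among the compounds named here.

Measured compounds:
compound 1 `O=C(NCc1ccc(CNS(=O)(=O)c2ccc([N+](=O)[O-])cc2)cc1)c1ccc(CNc2ncccn2)cc1`, in an assay on MDA-MB-231 cells for binding affinity to C-X-C chemokine receptor type 4 (Homo sapiens), read by microscopy, with stated times of 10 min and 30 min (on this read-out higher numbers stand for an effect only at larger amounts of compound and lower numbers for an effect already at smaller amounts), compound 1 gives 1000 nM
compound 2 `O=C(NCc1ccc(CNS(=O)(=O)c2cccc(C(F)(F)F)c2)cc1)c1ccc(CNc2ncccn2)cc1`, in this assay compound 2 gives 1000 nM
compound 3 `O=C(NCc1ccc(CNS(=O)(=O)c2ccc3c(c2)CCO3)cc1)c1ccc(CNc2ncccn2)cc1`, in this assay compound 3 gives 1000 nM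

Compound 2 stands level with compound 1 and compound 3; the three values lie within the scatter of one another, so no order among them can be read. All three share a common core and differ only in the group on the sulfonyl sulfur.

Compound 4 `O=C(NCc1ccc(CNS(=O)(=O)c2cccc(F)c2)cc1)c1ccc(CNc2ncccn2)cc1` differs from compound 2 by fluoro in place of trifluoromethyl on an aromatic carbon. Every step measured so far changes this same group on the sulfonyl sulfur and leaves the read-out where it was: no change at the digits printed from compound 1 to compound 2 (within the scatter), no change at the digits printed from compound 1 to compound 3 (within the scatter) and no change at the digits printed from compound 2 to compound 3 (within the scatter). The exchange of trifluoromethyl for fluoro is a smaller change than any of those, so the expected step is no change at the digits printed from compound 2 to compound 4 (within the scatter), none beyond the scatter. For compound 4 in this assay the estimate is therefore 1000 nM, with a range from 500 nM to 2000 nM.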

Compound 4, effective concentration (reported as EC, without a stated level of effect): 1000 nM
Estimate against measurement, compound 4: no gap at the digits printed, and the stated range covers the measured number.
By their numbers in this assay, from the lowest: compounds 1, 2, 3 and 4 (each within the scatter of the next).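

In this assay, among these compounds, the exchange of trifluoromethyl for fluoro gives no change at the digits printed from compound 2 to compound 4 (within the scatter); unlike the earlier steps, this one keeps the same position on the aromatic ring and alters only the single substituent there. The other two steps read the same way, with no change at the digits printed from compound 3 to compound 4 (within the scatter) and no change at the digits printed from compound 1 to compound 4 (within the scatter), so 3-fluorophenyl on the sulfonyl sulfur also stands level with the groups seen before. Nothing available explains why the read-out stays flat across these groups.

As far as these compounds go, whether an amine or a carboxylic acid on this aromatic ring, or a longer alkyl chain on the sulfonyl sulfur in place of the ring, would move the read-out stays open. The compounds shown also leave open what a change in the shared core would do.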